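Phenyl replacing thiophen-3-yl: compound 3 to compound 4

The compounds below may be only part of what the source reports. "The series", "measured", "known", "first", "only" and "open" are said of these compounds alone.

Three compounds of the series have been run in an ADME assay on BJ cells (Homo sapiens), read by MTT assay, with a stated time of 72 h (a lower number here means a stronger inhibitor, a higher number a weaker inhibitor), so far, and none has given a number. Compound 1 `Nc1nc(N)c2c(-c3ccsc3)cn([C@@H]3O[C@H](CO)[C@@H](O)[C@H]3O)c2n1` reports a limit, > 100000 nM. Compound 2 `COc1ncnc2c1c(-c1ccccc1)cn2[C@@H]1O[C@H](CO)[C@@H](O)[C@H]1O` likewise reports only the limit > 100000 nM. Compound 3 `CNc1ncnc2c1c(-c1ccsc1)cn2[C@@H]1O[C@H](CO)[C@@H](O)[C@H]1O`, which carries the thiophen-3-yl, stands at the same limit, > 100000 nM. All three values therefore sit together at the limit of > 100000 nM in this assay, at which 3 of the 3 values shown sit, and no ordering among them can be drawn.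

Compound 4 `CNc1ncnc2c1c(-c1ccccc1)cn2[C@@H]1O[C@H](CO)[C@@H](O)[C@H]1O` is the next to be measured in this assay. It differs from compound 3 in one place: phenyl in place of thiophen-3-yl on an aromatic carbon. For the measured compounds named here, no step between two measured compounds is available for this change, so its size can only be judged from the surroundings. Compound 2 already carries a phenyl on the same aromatic carbon and stops at the limit, and compound 3 with the thiophen-3-yl stops there too, so no step beyond the scatter is expected in this assay in either direction. The expected step is a step that the limit leaves unreadable from compound 3 to compound 4. For compound 4 the estimate in this assay is 150000 nM, with a range from 50000 nM to 500000 nM, most likely reported again only as a limit.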

Compound 4, half-maximal inhibitory concentration: > 100000 nM
Compound 4 was reported as a limit; the forecaster's own chance of this, stated with the estimate: 85%; the middle value does not contradict the limit.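

Compound 4 reports only a limit in this assay, as do compound 2 and compound 3, so neither the step from compound 3 nor the step from compound 2 can be read: the limit of > 100000 nM in this assay, at which 4 of the 4 values shown sit.

The compounds shown leave open how phenyl and thiophen-3-yl, or methylamino and methoxy, compare in this assay.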